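Adding a Methoxy Group to a Weakly Acting Compound

The source may hold more compounds than are shown below. What is called first, only, known or untested is meant among the compounds shown, and "the series" means these compounds.

A pair of measured compounds frame this account. Compound 1 `COc1ccc(-c2cc(/C=C/C(=O)c3ccc(N)cc3)[nH]n2)cc1` and compound 2 `COc1cc(-c2cc(/C=C/C(=O)c3ccc(Cl)c(Cl)c3)[nH]n2)cc(OC)c1OC` were both tested in a functional assay on HCT-116 cells (Homo sapiens) for cytotoxicity, read by sulforhodamine B assay, with a stated time of 48 h, tested at 0.1 uM; a lower number here means a stronger effect, a higher number a weaker effect of the compound at the concentration tested. In this assay compound 1 gives 105%, and compound 2 gives 100%. Compound 1 holds the highest of the two numbers, with compound 2 nearest to it at a gap that lies within the usual scatter, so the two readings cannot be told apart. Both sit near the level of untreated cells, and neither compound shows a clear effect at the concentration tested.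

Compound 3 `COc1ccc(-c2cc(/C=C/C(=O)c3ccc(N)cc3)[nH]n2)cc1OC` has not yet been measured. It differs from compound 1 by methoxy in place of hydrogen on an aromatic carbon. Within the data shown here, no step of this kind between measured compounds is available, so the expectation rests on compound 1 alone: because compound 1 gives 105% in this assay, a reading at the weak end, the expected step is a number 5 percentage points lower from compound 1 to compound 3 (within the scatter), none beyond the scatter in either direction. Compound 3 is therefore expected to give 100% in this assay, estimated within a range from 85% to 112%.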

Compound 3, a percentage reported as activity, at one concentration (the size of the read-out at that concentration, not a potency): 101%
The estimate for compound 3 lay 1 percentage points below the measured number; the measured number falls inside the stated range.
By their numbers in this assay, from the lowest: compounds 2, 3 and 1 (each within the scatter of the next).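

In this assay methoxy in place of hydrogen on an aromatic carbon, ortho to a methoxy group and meta to a large group, gives a number 4 percentage points lower from compound 1 to compound 3 (within the scatter) and so the two readings cannot be told apart. Among these compounds, this is the first step between measured compounds that differ in one place, and it shows that at this position the added methoxy alone does not bring out a clear effect at the concentration tested, as compound 3 stays near the level of untreated cells alongside compound 1. No measurement at hand bears on why this step is so small.

The compounds shown leave open whether another group on this same aromatic carbon, such as a hydroxyl, a fluorine atom or an ethoxy group, would give a reading that stands apart from that of compound 1. They also leave open whether the same methoxy step would matter on a compound with a clear effect at this concentration, since every reading so far sits at the weak end, where a real difference between compounds may not show.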